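The source may report more compounds than this note shows. Statements on the series, on what has been measured and on what is new or still open speak of the compounds shown alone.

Compound 1 `O=C(O)c1cccc(NC(=O)c2ccc(OCc3cccc(-c4ccccc4)c3)cc2)c1` gives 319 nM in an assay on isolated protein for agonist activity at Bile acid receptor (Homo sapiens), read by TR-FRET, with a stated time of 3 h, in the absence of a further agent; a higher number here means that more compound is needed for the effect, a lower number that less compound is needed. Compound 2 `Cc1ccccc1-c1cccc(COc2ccc(C(=O)Nc3cccc(C(=O)O)c3)cc2)c1` carries the change methyl in place of hydrogen on an aromatic carbon and gives 1030 nM, so that a 3.2-fold higher number from compound 1 to compound 2 (0.51 log units; beyond the scatter). Compound 3 `O=C(O)c1cccc(NC(=O)c2cccc(OCc3ccccc3)c2)c1` gives 1160 nM; how its core differs from the core of compound 1 is not broken down here. Compound 4 `Cc1cccc(COc2cccc(C(=O)Nc3cccc(C(=O)O)c3)c2)c1` is not yet measured and differs from compound 3 by methyl in place of hydrogen on an aromatic carbon. Within the data shown here, this is the same kind of change as the one from compound 1 to compound 2, but not the same: there the methyl sits ortho to a large group, here meta to a large group. Given that earlier step, compound 4 is expected to move a 1.7-fold higher number from compound 3 to compound 4 (0.24 log units; within the scatter) in this assay, with wide uncertainty because the surroundings differ. The estimate for compound 4 is 2000 nM, from 900 nM to 5000 nM.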

Compound 4, half-maximal effective concentration: 1860 nM
The estimate for compound 4 lay 1.1-fold (0.03 log units) above the measured number, within the range that was stated.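

In this assay, going from benzyl to 3-methylbenzyl gives a 1.6-fold higher number from compound 3 to compound 4 (0.21 log units; within the scatter). Set beside the earlier step, the methyl shows no difference between the two cores that can be told from scatter: the same change on two cores in this assay, a 3.2-fold higher number (0.51 log units; beyond the scatter) from compound 1 to compound 2 and a 1.6-fold higher number (0.21 log units; within the scatter) from compound 3 to compound 4, 2.0-fold (0.30 log units) apart, within the scatter of two such steps This does not show that the change carries over equally from core to core: there are only two pairs, the methyl sits in a different place in each, and a step within the scatter cannot be told from no change.

The compounds shown leave open whether a methyl meta to a large group on the core of compound 1 would give a similar step. Also open, as far as these compounds go, is how a chlorine, a methoxy group or an amine would compare at the same place.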